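Fluoro for bromo: from compound 3 to compound 4

The source may hold more compounds than are shown below. What is called first, only, known or untested is meant among the compounds shown, and "the series" means these compounds.

Going by the values given here, in an ADME assay on THP-1 cells (Homo sapiens) for cytotoxicity, read by flow cytometry and propidium iodide staining, with a stated time of 72 h (a higher number here means a weaker inhibitor, a lower number a stronger inhibitor), compound 3 `Cc1nc(CS(=O)(=O)c2ccc(Br)cc2)c([N+](=O)[O-])n1CC(C)O` gives 126000 nM, the lower of the two numeric values so far. Compound 2 `Cc1nc(CS(=O)(=O)c2ccccc2)c([N+](=O)[O-])n1CC(C)O` gives 418000 nM. Compound 1 `Cc1nc(CS(=O)(=O)c2ccc(F)cc2)c([N+](=O)[O-])n1C`, which carries a 4-fluorophenyl group, is reported only as a limit, > 797000 nM.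

Compound 4 `Cc1nc(CS(=O)(=O)c2ccc(F)cc2)c([N+](=O)[O-])n1CC(C)O` has fluoro in place of bromo on an aromatic carbon, para to a large group: fluoro in place of bromo on an aromatic carbon. Among the compounds with values here, one measured step bears directly on this position: bromo in place of hydrogen, a 3.3-fold lower number from compound 2 to compound 3 (0.52 log units; beyond the scatter). Within the data shown here, no measured pair compares fluoro with bromo or with hydrogen, so the reading is indirect. Removing the bromo is expected to reverse most of that step, leaving a value near compound 2 at 418000 nM.

The step expected in this assay is a 2.5-fold higher number from compound 3 to compound 4 (0.40 log units; beyond the scatter), towards a higher number and modest in size. Compound 4 is estimated at 320000 nM, with an expected range of 150000 nM to 700000 nM.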

Compound 4, half-maximal inhibitory concentration: > 699000 nM
Compound 4 gave a limit, no number (the forecaster's own chance of this, stated with the estimate: 15%); middle value at least 2.1-fold (0.33 log units) away from the limit.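

In this assay, the change from 4-bromophenyl to 4-fluorophenyl gives an at least 5.5-fold higher number from compound 3 to compound 4 (0.74 log units; beyond the scatter), so the lower number at this position goes with bromo in particular and not with any halogen on this aromatic carbon. Fluoro against hydrogen stays unordered, with an at least 1.6-fold higher number from compound 2 to compound 4 (0.22 log units; that floor lies within the scatter), so among compounds 2, 3 and 4 only compound 3 stands apart. Compound 4 is reported only as a limit, and the step from compound 1 to compound 4 cannot be read: the limit of > 699000 nM in this assay, at which 1 of the 4 values shown sits.

Still open, going by these compounds, is whether chloro, methoxy or an amine on this carbon would give a lower number, as bromo does in compound 3. Also open, on these data alone, is whether bromo would give the same step with a longer chain in place of 1-hydroxyethyl on the aromatic nitrogen.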